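Cyclopropyl to cyclopropylmethyl on the ring nitrogen of compound 1

The source may report more compounds than this note shows. Statements on the series, on what has been measured and on what is new or still open speak of the compounds shown alone.

Measured so far in an ADME assay on microsomes from liver (Rattus norvegicus) for metabolic stability, read by LC-MS, with a stated time of 1 h, at 37 degrees C, tested at 4 uM; a higher number here means that more of the compound is left, a lower number that less of the compound is left:
- compound 1 `O=C(O)c1cc(-c2cccc(COc3ccc4c(=O)n(C5CC5)sc4c3)c2)ccc1Cl` gives 86%
- compound 3 `O=C(O)c1cc(-c2cccc(-c3ccc4c(c3)CN(C3CCCC3)C4=O)c2)ccc1Cl` gives 70%
- compound 2 `O=C1c2ccc(OCc3cccc(-c4ccc(C(F)(F)F)cc4F)c3)cc2CN1C1CCCC1` gives "not determined" (no result reported), so no result is reported for it

Compound 1 stands highest of the two numbers available in this assay; the nearest entry is compound 3, whose value lies below that of compound 1 by a margin beyond the usual scatter. Compound 2 adds no number to compare against. For the measured compounds named here, no pair among the measured compounds differs in just one place, so no measured step is available as a guide for the change considered here.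

The unmeasured compound 4 `O=C(O)c1cc(-c2cccc(COc3ccc4c(=O)n(CC5CC5)sc4c3)c2)ccc1Cl` differs from compound 1 in one place: cyclopropylmethyl in place of cyclopropyl on an aromatic nitrogen. The shared core and the acid-bearing side of the molecule are unchanged.

Going by the values given here, with only one measured neighbour and no single-point step to lean on, the expectation rests on the value of compound 1, 86%, as the starting point. A small step is expected in this assay, downward rather than upward, and it may well stay within the scatter of repeated measurements: the estimated step is a number 10 percentage points lower from compound 1 to compound 4 (within the scatter). For compound 4 the estimated value in this assay is 76%, with a range from 55% to 92%.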

Compound 4, percent of the compound remaining: 75%
Compound 4: the middle estimate sits 1 percentage points above what was measured; measured number inside the range.
By their numbers in this assay, from the lowest: compounds 3 and 4 (each within the scatter of the next); then compound 1.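

In this assay, the aromatic nitrogen next to the ring sulfur now has its first step that changes one place only: cyclopropylmethyl in place of cyclopropyl gives a number 11 percentage points lower from compound 1 to compound 4 (beyond the scatter), a modest step. The substituent on this nitrogen therefore matters to the read-out, since a change that keeps the three-membered ring of carbon only and leaves the shared core and the acid-bearing side untouched is enough to move the percent remaining past the usual scatter, though this rests on a single pair. No measurement at hand accounts for the step, so the result stands as an observation on this pair and nothing more.

Still open, on these data alone, is whether the trend continues on this nitrogen with a longer chain such as n-butyl, or whether it reverses with a smaller group such as methyl, which would show if cyclopropyl in compound 1, at 86%, is a special case or one point on a slope. Also open, as far as these compounds go, is how a chain ending in a hydroxyl or an amine on the same nitrogen would read in this assay.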